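The source may report more compounds than this note shows. Statements on the series, on what has been measured and on what is new or still open speak of the compounds shown alone.

Compound 2 `O=C(COc1cccc2ccccc12)N/N=C/c1cccc(Br)c1` and compound 1 `O=C(COc1cccc2ccccc12)N/N=C/c1cccc(O)c1` share one core and differ only by hydroxy in place of bromo on an aromatic carbon. In an ADME assay on MT4 cells (Homo sapiens) for cytotoxicity, read by MTT assay, with a stated time of 4 days (a lower number here means that less compound is tolerated, a higher number that more compound is tolerated), compound 2 gives 87.4 ug/mL, while compound 1 gives 32.6 ug/mL; the step of a 2.7-fold lower number from compound 2 to compound 1 (0.43 log units; beyond the scatter) lies beyond the usual scatter, so less of compound 1 is tolerated than of compound 2.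

Compound 3 `C/C(=N\NC(=O)COc1cccc2ccccc12)c1ccc(Br)cc1` belongs to a second core; the difference between the two cores is not broken down here. In this assay compound 3 gives 77.6 ug/mL. This number lies within the scatter of compound 2 and beyond the scatter of compound 1, so compound 3 and compound 2 cannot be ordered against each other, whereas compound 1 clearly sits lower than both.

Compound 4 `C/C(=N\NC(=O)COc1cccc2ccccc12)c1ccc(O)cc1` has not yet been measured. It differs from compound 3 by hydroxy in place of bromo on an aromatic carbon. For the measured compounds named here, this is the same kind of change as the one from compound 2 to compound 1, but not the same: in the earlier pair the entering group sits meta to a large group, here it sits para to a large group. Only one measured step of this kind exists among these compounds, so any expectation rests on it alone. Going by the values given here, a step of about a 2.6-fold lower number from compound 3 to compound 4 (0.41 log units; beyond the scatter) is expected in this assay because a 2.7-fold lower number from compound 2 to compound 1 (0.43 log units; beyond the scatter) is the sole precedent for the change. Compound 4 is therefore estimated at 30 ug/mL, with a range expected from 15 ug/mL to 60 ug/mL.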

Compound 4, half-maximal cytotoxic concentration: 68.8 ug/mL
The estimate for compound 4 lay 2.3-fold (0.36 log units) below the measured number, outside the stated range (above it).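

In this assay, replacing bromo with hydroxy on the core of compound 3 gives a 1.1-fold lower number from compound 3 to compound 4 (0.05 log units; within the scatter), so on this core the 4-bromophenyl and 4-hydroxyphenyl compounds cannot be ordered against each other. Set beside the earlier pair, this step cannot be told apart from it: the same change on two cores in this assay, a 2.7-fold lower number (0.43 log units; beyond the scatter) from compound 2 to compound 1 and a 1.1-fold lower number (0.05 log units; within the scatter) from compound 3 to compound 4, 2.4-fold (0.38 log units) apart, within the scatter of two such steps. The two pairs therefore show neither that the change carries over from one core to the other with a fixed size nor that its size depends on the core, and since they differ in the core as well as in where the group sits, two pairs could not separate those two influences.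

The compounds shown leave open how an amine, a carboxylic acid or a methoxy group would read in place of bromo or hydroxy in this assay, and whether hydroxy in place of bromo would give matching steps if the group sat in the same place on both cores. They also leave open what the difference between the two cores contributes by itself, as no pair shown differs in that alone.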